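The source may report more compounds than this note shows. Statements on the series, on what has been measured and on what is new or still open speak of the compounds shown alone.

For the measured compounds named here, in a functional assay on HeLa cells (Homo sapiens) for antiproliferative activity, read by resazurin assay (on this read-out lower numbers stand for stronger inhibition and higher numbers for weaker inhibition), compound 2 `CCSC(=S)SCC(=O)c1ccc(OC)cc1` gives 2510 nM, the lowest of the two numbers known so far. Going by the values given here, compound 1 `CCSC(=S)SCC(=O)c1ccc(S(N)(=O)=O)cc1` gives 20000 nM in this assay, and the one measured step, an 8.0-fold lower number from compound 1 to compound 2 (0.90 log units; beyond the scatter), concerns a change at the aromatic carbon, not at the oxygen. Compound 3 `CCSC(=S)SCC(=O)c1ccc(OC(F)F)cc1` is not yet measured. Among the compounds with values here, its difference from compound 2 is difluoromethyl in place of methyl on an oxygen on an aromatic ring No measured step touches the methyl on this oxygen, so the single known step gives no guide to how large this change might be in this assay. Lacking a comparable step, the number for compound 3 is expected to stay close to that of compound 2. The step of a 1.0-fold lower number from compound 2 to compound 3 (0.00 log units; within the scatter) is therefore expected to be none beyond the scatter. Compound 3 is estimated at 2500 nM, within a range from 800 nM to 8000 nM.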

Compound 3, half-maximal inhibitory concentration: 3980 nM
Beside the measured number, compound 3's estimate is 1.6-fold (0.20 log units) below it; the range from low to high includes it.
By their numbers in this assay, from the lowest: compounds 2 and 3 (each within the scatter of the next); then compound 1.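

In this assay the methyl on this oxygen gives way to difluoromethyl with a 1.6-fold higher number from compound 2 to compound 3 (0.20 log units; within the scatter), so the two fluorine atoms bring no change here that can be told from the scatter. Measured against sulfamoyl on the aromatic carbon, difluoromethoxy gives a 5.0-fold lower number from compound 1 to compound 3 (0.70 log units; beyond the scatter), so the gap first seen with methoxy also holds for a second oxygen-linked group, and compound 2 and compound 3 both stand apart from compound 1. Nothing available explains why these two groups read alike or why the sulfamoyl compound stands apart.

The compounds shown leave open how a longer chain on this oxygen, such as propyl or butyl, would read in this assay. They also leave open whether a group with no oxygen on the aromatic carbon, such as an amine or a chlorine atom, would fall with compound 2 and compound 3 or with compound 1.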